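Swapping the aryl group on the core of compound 1

The compounds below may be only part of what the source reports. "The series", "measured", "known", "first", "only" and "open" are said of these compounds alone.

Measured compounds:
compound 1, `NS(=O)(=O)c1ccc(-c2nc(C(c3ccc(F)cc3)c3ccc(F)cc3)sc2CC(=O)O)cc1`, > 100000 nM
compound 2, `O=C(O)Cc1sc(C2COc3ccccc3O2)nc1-c1ccc(Cl)cc1`, 2000 nM
compound 3, `O=C(O)Cc1sc(C(c2ccccc2)c2ccccc2)nc1-c1cccc(F)c1`, 29 nM

In an in vitro functional assay on HEK285-7 cells for antagonist activity at prostaglandin D2 receptor 2 (Homo sapiens), read by BRET and beta-arrestin recruitment (on this read-out lower numbers stand for stronger inhibition and higher numbers for weaker inhibition), compound 1 gives only a limit, (the limit of > 100000 nM in this assay, at which 1 of the 3 values shown sits), and no number. For the measured compounds named here, compound 3 is the one with the lowest number among the three, and compound 2 lies well inside the measurable range. The unmeasured compound 4, `O=C(O)Cc1sc(C(c2ccc(F)cc2)c2ccc(F)cc2)nc1-c1ccnc(O)c1`, departs from compound 1 in one place: 2-hydroxypyridin-4-yl in place of 4-sulfamoylphenyl on an aromatic carbon. Going by the values given here, no step between two measured compounds links this change to a known shift, so the expectation rests on where compound 1 stands and on the diaryl methyl pattern that compound 3 also carries. Because compound 1 sits at the limit of > 100000 nM in this assay, at which 1 of the 3 values shown sits, the step of an at least 33-fold lower number from compound 1 to compound 4 (1.52 log units; beyond the scatter) is expected to bring compound 4 into the measurable range, though not as far as compound 3. Compound 4 is estimated at 3000 nM, with a range from 300 nM to 30000 nM.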

Compound 4, half-maximal inhibitory concentration: 890 nM
Compound 4: middle estimate off by 3.4-fold (0.53 log units), on the high side; the range from low to high includes it.
By their numbers in this assay, from the lowest: compound 3; then compound 4; then compound 2. At a limit, above all of these: compound 1.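

In this assay, the aromatic carbon next to the ring nitrogen proves decisive for this series: with the rest of the structure kept, 2-hydroxypyridin-4-yl in place of 4-sulfamoylphenyl gives an at least 110-fold lower number from compound 1 to compound 4 (2.05 log units; beyond the scatter). The earlier compounds shown here differ from one another in more than one place and isolate no single position, whereas this pair ties the shift to this one change. The printed step is a bound and not an exact size, since compound 1 stands at a limit: the limit of > 100000 nM in this assay, at which 1 of the 4 values shown sits.

The change replaces the ring, the sulfamoyl group and the hydroxyl group at once, and this pair cannot separate their contributions. The compounds shown leave open how a 4-aminophenyl group or an unsubstituted pyridin-4-yl group at this carbon would read in this assay with the rest of compound 4 kept.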